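Chloro added to a phenyl ring on the shared core

A few compounds are considered here, and "the series" means these few. Any claim that something is new, unique, unknown or untested is made for them only; others in the source may bear on it.

Compound 1 `Cc1ccc(-c2cc3n(n2)CCCC3)nc1` — 3000 nM
Compound 2 `c1ccc(-c2cc3n(n2)CCCC3)cc1` — 1900 nM
Compound 3 `Clc1ccccc1-c1cc2n(n1)CCCC2` — 2650 nM

These three compounds share a core and differ only in the aromatic ring attached to it. In a functional assay on HEK293 cells for negative allosteric modulation of metabotropic glutamate receptor 5 (Rattus norvegicus), read by FLIPR and calcium flux, with a stated time of 170 s (on this read-out higher numbers stand for weaker inhibition and lower numbers for stronger inhibition), compound 2 gives 1900 nM, the lowest of the three numbers, but its neighbours are close: compound 3 gives 2650 nM and compound 1 gives 3000 nM, and both gaps are within the scatter, so no order among them can be claimed.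

Compound 4 `Clc1cccc(-c2cc3n(n2)CCCC3)c1` differs from compound 2 by chloro in place of hydrogen on an aromatic carbon. Within the data shown here, the one measured step that bears on this is the same kind of change: a 1.4-fold higher number from compound 2 to compound 3 (0.14 log units; within the scatter), a chloro in place of hydrogen on the same ring, which left the number essentially unchanged. On that basis, and with nothing pointing the other way, the step in this assay is expected to be small, in no clear direction, and not beyond the scatter. Compound 4 is therefore expected to give about 1700 nM, plausibly between 600 nM and 5000 nM. The expected change is a 1.1-fold lower number from compound 2 to compound 4 (0.05 log units; within the scatter).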

Compound 4, half-maximal inhibitory concentration: 77 nM
Estimate against measurement, compound 4: 22-fold (1.34 log units) above; measured number outside the range, below it.
By their numbers in this assay, from the lowest: compound 4; then compounds 2, 3 and 1 (each within the scatter of the next).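

In this assay, the same swap of hydrogen for chloro on the phenyl ring has very different outcomes: with the chloro meta to a group of 9 heavy atoms, compound 4 shows a large step (a 25-fold lower number from compound 2 to compound 4 (1.39 log units; beyond the scatter)), whereas the chloro of compound 3, on another carbon of the same ring, shows only a small one (a 1.4-fold higher number from compound 2 to compound 3 (0.14 log units; within the scatter)). In these compounds, then, the outcome depends on which ring carbon carries the chloro, so one chloro result does not predict another on the same ring. Nothing available explains why this position stands out so sharply.

The compounds shown leave open whether the step belongs to chloro itself or would also appear with a fluoro, a methoxy or a nitrile on that same carbon. They also leave open whether a chloro at the matching place on the ring of compound 1 would produce a similar step.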